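Para-substituent removal on the sulfonamide aryl ring

The compounds below may be only part of what the source reports. "The series", "measured", "known", "first", "only" and "open" are said of these compounds alone.

Measured compounds:
Compound 1, `Cc1ccc(S(=O)(=O)Nc2ccc3c(c2)c(Cc2ccc(F)cc2)cn3CCC(=O)O)cc1`: 0.269 nM
Compound 2, `O=C(O)CCn1cc(Cc2ccc(F)cc2)c2cc(NS(=O)(=O)c3ccc(Cl)cc3)ccc21`: 0.234 nM

In a functional assay on aorta for antagonist activity at thromboxane A2 receptor (Rattus norvegicus) (a lower number here means tighter binding, a higher number weaker binding), compound 2 gives 0.234 nM. Going by the values given here, the only other number in this assay belongs to compound 1, and the step from compound 1 to compound 2 is a 1.1-fold lower number from compound 1 to compound 2 (0.06 log units; within the scatter), so the two compounds cannot be ranked against each other on these data.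

Compound 3, `O=C(O)CCn1cc(Cc2ccc(F)cc2)c2cc(NS(=O)(=O)c3ccccc3)ccc21`, is not yet measured in this assay. It differs from compound 2 by hydrogen in place of chloro on an aromatic carbon.

Among the compounds with values here, one measured step touches the same position: chloro in place of methyl, a 1.1-fold lower number from compound 1 to compound 2 (0.06 log units; within the scatter), within the scatter. Exchanging one small substituent for another at this carbon therefore left the dissociation constant essentially unchanged. Within the data shown here, removing the substituent altogether is a somewhat different change, and no measured pair covers it, so the expectation rests on a single within-scatter step. The working expectation is a small step at most, if anything toward a higher number, a 1.7-fold higher number from compound 2 to compound 3 (0.23 log units; within the scatter), not clearly beyond the scatter.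

Compound 3 is thus expected to give about 0.4 nM in this assay, with a range of 0.15 nM to 1.2 nM.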

Compound 3, dissociation constant: 0.676 nM
Beside the measured number, compound 3's estimate is 1.7-fold (0.23 log units) below it; the measured number falls inside the stated range.
By their numbers in this assay, from the lowest: compounds 2 and 1 (each within the scatter of the next); then compound 3.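

In this assay, this carbon, para to a large group, proves sensitive to losing its substituent in a way that the exchange of one substituent for another did not show: hydrogen in place of chloro gives a 2.9-fold higher number from compound 2 to compound 3 (0.46 log units; beyond the scatter), and hydrogen in place of methyl gives a 2.5-fold higher number from compound 1 to compound 3 (0.40 log units; beyond the scatter), whereas chloro in place of methyl gives only a 1.1-fold lower number from compound 1 to compound 2 (0.06 log units; within the scatter). Among these three compounds, the 4-chlorophenyl and the 4-methylphenyl sulfonamides therefore stay together and the plain phenylsulfonyl compound stands apart on the weaker side, with none of the three going against this, though both steps to compound 3 are modest. No measurement shown here bears on the reason for this loss.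

On these data alone, whether the number stays low with other groups on this carbon, such as methoxy, trifluoromethyl, bromo or an amine, remains open, so two substituents cannot show what is required of one here. Also open, as far as these compounds go, is whether chloro elsewhere on the six-membered ring would do the same, and whether the step holds with a different group in place of the 4-fluorobenzyl part of the shared core.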